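A few compounds are considered here, and "the series" means these few. Any claim that something is new, unique, unknown or untested is made for them only; others in the source may bear on it.

Compound 1 `CCN(CC)C/C=C/C(=O)Nc1cc2c(N3CCc4ccccc43)ncnc2cc1OC` and compound 2 `COc1cc2ncnc(N3CCc4ccccc43)c2cc1NC(=O)/C=C/CN1CCCC1` share one core and differ in a single place, (pyrrolidin-1-yl in place of diethylamino on a saturated chain carbon bound to a double-bonded chain carbon). In a functional assay on A549 cells (Homo sapiens) for antiproliferative activity, read by MTT assay, with a stated time of 72 h (a lower number here means a stronger inhibitor, a higher number a weaker inhibitor), compound 1 gives 1690 nM, and compound 2 gives 1210 nM, so that a 1.4-fold lower number from compound 1 to compound 2 (0.15 log units; within the scatter). Compound 3 `CCN(CC)C/C=C/C(=O)Nc1cc2c(N3CCCc4ccccc43)ncnc2cc1O[C@@H]1CCOC1` carries a core whose difference from that of compound 1 is not broken down here; in this assay compound 3 gives 5650 nM, the highest of the three numbers and beyond the scatter from both compound 1 and compound 2. Compound 4 `O=C(/C=C/CN1CCCC1)Nc1cc2c(N3CCCc4ccccc43)ncnc2cc1O[C@@H]1CCOC1` is not yet measured and differs from compound 3 by pyrrolidin-1-yl in place of diethylamino on a saturated chain carbon bound to a double-bonded chain carbon, the same change, at the same place, that carries compound 1 to compound 2. The step of a 1.3-fold lower number from compound 3 to compound 4 (0.13 log units; within the scatter) is expected to be of like size, because the same change gave a 1.4-fold lower number from compound 1 to compound 2 (0.15 log units; within the scatter). Compound 4 is therefore estimated at 4200 nM, between 2000 nM and 8500 nM.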

Compound 4, half-maximal inhibitory concentration: 6510 nM
Compound 4: middle estimate off by 1.6-fold (0.19 log units), on the low side, and the stated range covers the measured number.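

In this assay the exchange of diethylamino for pyrrolidin-1-yl gives a 1.2-fold higher number from compound 3 to compound 4 (0.06 log units; within the scatter), so on this second core the change again leaves the number within the scatter. The two steps agree, and the change carries from the core of compound 1 to the core of compound 3 as a step too small to read: the same change on two cores in this assay, a 1.4-fold lower number (0.15 log units; within the scatter) from compound 1 to compound 2 and a 1.2-fold higher number (0.06 log units; within the scatter) from compound 3 to compound 4, 1.6-fold (0.21 log units) apart, within the scatter of two such steps. This shows that the exchange made no clear difference in these two pairs in this one assay; it does not show how it would behave on other cores or in other read-outs, and two steps this small give no direction for it.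

The compounds shown leave open whether another amine on the same chain, such as dimethylamino, piperidin-1-yl or morpholin-4-yl, would move the number beyond the scatter. They also leave open whether a longer chain carrying the pyrrolidin-1-yl would do so.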